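Swapping the bicyclic arm for a methoxybenzyl group

The source may report more compounds than this note shows. Statements on the series, on what has been measured and on what is new or still open speak of the compounds shown alone.

The compounds share a bis(trifluoromethyl)benzenesulfonamide core linked through a short diamine chain to an aromatic arm. Compound 1 `O=S(=O)(NCCNCc1cccc2ccccc12)c1cc(C(F)(F)F)cc(C(F)(F)F)c1` carries a naphthylmethyl arm, and in a functional assay on A2780 cells (Homo sapiens) for inhibition, read by MTT assay, with a stated time of 72 h (a higher number here means a weaker inhibitor of growth, a lower number a stronger inhibitor of growth), compound 1 gives 21000 nM. Compound 2 `O=S(=O)(NCCCNCC1COc2ccccc2O1)c1cc(C(F)(F)F)cc(C(F)(F)F)c1` stands as the lower of the two numbers: in this assay compound 2 gives 1500 nM, a gap to compound 1 that lies beyond the scatter. Compound 3 `COc1ccc(CNCCCNS(=O)(=O)c2cc(C(F)(F)F)cc(C(F)(F)F)c2)cc1` has not yet been measured; its change from compound 2 is 4-methoxyphenyl in place of 2,3-dihydro-1,4-benzodioxin-2-yl on a saturated chain carbon bound to an amine nitrogen. Going by the values given here, no measured pair in this set shows this change, so its effect is unknown. Because compound 2 reaches 1500 nM with its arm, compound 3 is expected to lose a little, by a step of a 2.0-fold higher number from compound 2 to compound 3 (0.30 log units; within the scatter), near the edge of the scatter. In this assay compound 3 is estimated at 3000 nM, between 1000 nM and 10000 nM.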

Compound 3, concentration for 50% growth inhibition: 1700 nM
Estimate against measurement, compound 3: 1.8-fold (0.25 log units) above; low and high end bracket the measured number.
By their numbers in this assay, from the lowest: compounds 2 and 3 (each within the scatter of the next); then compound 1.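

In this assay, placing 4-methoxyphenyl where 2,3-dihydro-1,4-benzodioxin-2-yl stood, on a saturated chain carbon bound to an amine nitrogen, gives a 1.1-fold higher number from compound 2 to compound 3 (0.05 log units; within the scatter) and leaves the two arms indistinguishable. Going by these compounds alone, as the first comparison here of compounds differing in one place, it shows that this position accepts a single aromatic ring in place of the two-ring arm, with no change beyond the scatter. Nothing given here accounts for this result.

On these data alone, whether this tolerance extends to an unsubstituted benzyl, a 4-chlorobenzyl or a pyridylmethyl arm remains open. So does the effect of a shorter or longer chain with the 4-methoxybenzyl arm held in place.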